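A few compounds are considered here, and "the series" means these few. Any claim that something is new, unique, unknown or untested is made for them only; others in the source may bear on it.

Measured in a functional assay on K562 cells (Homo sapiens) for inhibition, read by fluorescence, with a stated time of 72 h; a lower number here means a stronger inhibitor of growth, a higher number a weaker inhibitor of growth:
- compound 1 `CC(C)CCn1cnc2c(Nc3ccc(Cl)cc3)nc(N[C@H]3CC[C@H](N)CC3)nc21`: 1800 nM
- compound 2 `CCCCCCn1cnc2c(Nc3ccc(Cl)cc3)nc(N[C@H]3CC[C@H](N)CC3)nc21`: 2100 nM
- compound 3 `N[C@H]1CC[C@H](Nc2nc(Nc3ccc(Cl)cc3)c3ncn(C4CCCCC4)c3n2)CC1`: 1700 nM

Compound 2, at 2100 nM, stands level with the other two compounds, since all three values lie within the scatter of one another. Compound 4 `CCCCCCn1cnc2c(Nc3cc(OC)cc(OC)c3)nc(N[C@H]3CC[C@H](N)CC3)nc21` differs from compound 2 by one change: 3,5-dimethoxyphenyl in place of 4-chlorophenyl on a nitrogen on an aromatic ring. The measured steps are a 1.2-fold higher number from compound 1 to compound 2 (0.07 log units; within the scatter), a 1.1-fold lower number from compound 1 to compound 3 (0.02 log units; within the scatter) and a 1.2-fold lower number from compound 2 to compound 3 (0.09 log units; within the scatter). All three are small, but they only exchange the isopentyl, hexyl and cyclohexyl groups on the aromatic nitrogen. For the measured compounds named here, the 4-chlorophenyl group is common to all three compounds, so no measured step bears directly on replacing it. The data therefore give no direction, and no step beyond the scatter is expected in this assay by default, although this expectation is weakly founded. The expected size is no change at the digits printed from compound 2 to compound 4 (within the scatter), an estimate that leaves the direction open. The estimate for compound 4 is 2100 nM, with an expected range from 600 nM to 8000 nM.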

Compound 4, concentration for 50% growth inhibition: 1900 nM
Compound 4: the middle estimate sits 1.1-fold (0.04 log units) above what was measured; the measured number falls inside the stated range.
By their numbers in this assay, from the lowest: compounds 3, 1, 4 and 2 (each within the scatter of the next).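

For the compounds shown here, the step from 4-chlorophenyl to 3,5-dimethoxyphenyl is the first to touch this nitrogen on an aromatic ring, as the earlier steps only exchanged the groups on the other, aromatic nitrogen. In this assay the result is a 1.1-fold lower number from compound 2 to compound 4 (0.04 log units; within the scatter), so with hexyl held fixed, a change that removes the chlorine and brings in two oxygens and 2 hydrogen-bond acceptors leaves the number within the scatter. No measured evidence bears on this outcome.

Whether the same holds with isopentyl or cyclohexyl on the aromatic nitrogen remains open, as this exchange is shown only with hexyl. As far as these compounds go, it is also open whether an amine or a carboxylic acid on the phenyl ring would give a step beyond the scatter.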